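Compound 3 to compound 4: one methyl returned

This account rests on a few compounds, and the source may have more. Where it says the series, first, only, none or still open, it means among the compounds named here.

In an assay on isolated protein for binding affinity to Leucine-rich repeat serine/threonine-protein kinase 2 (Homo sapiens), read by TR-FRET and LanthaScreen, with a stated time of 2 h (a lower number here means a stronger inhibitor, a higher number a weaker inhibitor), compound 3 `C[C@@H]1CCCN1c1c(C#N)c2c(N)nc(Nc3cn[nH]c3)nc2n1C` gives 0.2 nM, the lowest of the three numbers. Compound 1 `Cc1nn(C)cc1Nc1nc(N)c2c(C#N)c(N3CCC[C@H]3C)n(C)c2n1` gives 1 nM, and compound 2 `Cn1c(-n2cccc2)c(C#N)c2c(N)ncnc21` gives 239 nM. For the measured compounds named here, the only single-point step known, a 5.0-fold lower number from compound 1 to compound 3 (0.70 log units; beyond the scatter), replaced 1,3-dimethyl-1H-pyrazol-4-yl with 1H-pyrazol-4-yl. Compound 4 `Cc1n[nH]cc1Nc1nc(N)c2c(C#N)c(N3CCC[C@H]3C)n(C)c2n1` differs from compound 3 by methyl in place of hydrogen on an aromatic carbon, which reads 1H-pyrazol-4-yl to 3-methyl-1H-pyrazol-4-yl: one of the two methyls removed in that step is put back. That modest step is the one that bears here; a single methyl returning is expected to recover only part of it, toward a higher number, so a step of a 2.0-fold higher number from compound 3 to compound 4 (0.30 log units; within the scatter) is expected for compound 4. Compound 4 is estimated at 0.4 nM in this assay, with a range of 0.15 nM to 1.2 nM.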

Compound 4, inhibition constant: 1 nM
Compound 4: middle estimate off by 2.5-fold (0.40 log units), on the low side; the range from low to high includes it.
By their numbers in this assay, from the lowest: compound 3; then compounds 1 and 4 (each within the scatter of the next); then compound 2.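

In this assay, the methyl on the aromatic carbon alone accounts for the whole loss: 3-methyl-1H-pyrazol-4-yl gives (a 5.0-fold higher number from compound 3 to compound 4 (0.70 log units; beyond the scatter)), a step of the same size as the earlier removal of both methyls. The methyl on the aromatic nitrogen has no readable effect (no change at the digits printed from compound 1 to compound 4 (within the scatter)), so the two methyls do not contribute equally. No measurement available here explains this difference.

Still open, as far as these compounds go, is whether ethyl, methoxy or chlorine on that aromatic carbon would give a similar step, and whether a longer chain on the aromatic nitrogen would also leave the number unchanged.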